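Adding a Chloro Group to Compound 2

The source may hold more compounds than are shown below. What is called first, only, known or untested is meant among the compounds shown, and "the series" means these compounds.

Measured compounds:
compound 1 `O=C(O)CCC(=O)/C=C/c1cn(-c2ccccc2)nc1-c1ccccc1`, 27.9%
compound 2 `NC(=O)c1ccccc1NC(=O)c1cn(-c2ccccc2)nc1-c1ccccc1`, 17.7%

In a functional assay on the whole organism (strain albino) for inhibition, with Rattus norvegicus as the target, read by paw edema, with stated times of 30 min and 1 h, at a dose of 50 mg/kg by the oral route (on this read-out higher numbers stand for more inhibition at the one dose given (going by the name of the read-out) and lower numbers for less inhibition), compound 1 gives 27.9% and compound 2 gives 17.7%, the lower of the two numbers, with compound 1 standing beyond the scatter above it. Compound 3 `NC(=O)c1ccccc1NC(=O)c1cn(-c2ccccc2)nc1-c1ccc(Cl)cc1` has not been measured. It differs from compound 2 by chloro in place of hydrogen on an aromatic carbon, the same difference cut one bond further out reading phenyl to 4-chlorophenyl. Going by the values given here, no measured pair differs in only one place, so nothing shows how large such a step is. A small step is expected, not beyond the scatter, in either direction: a number 2.3 percentage points higher from compound 2 to compound 3 (within the scatter). Compound 3 is estimated at 20%, between 8% and 35%.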

Compound 3, a percentage reported as inhibition, in the whole organism at one dose (the size of the read-out at that dose, not a potency): 1.96%
Compound 3: the middle estimate sits 18 percentage points above what was measured; the whole stated range lies above it.
By their numbers in this assay, from the lowest: compound 3; then compound 2; then compound 1.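

In this assay this change gives the first step measured at a single place, a number 15.7 percentage points lower from compound 2 to compound 3 (beyond the scatter), and it lies beyond the usual scatter. The position on the aromatic ring para to a large group is therefore not indifferent: one chloro, a single heavy atom, removes most of the inhibition seen with hydrogen there at this dose. Nothing available explains this drop. Going by these compounds, whether fluoro, methyl or methoxy at the same place would lower the number as well remains open, and so does whether an amine there would keep the inhibition.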